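The source may hold more compounds than are shown below. What is called first, only, known or untested is meant among the compounds shown, and "the series" means these compounds.

In an assay on isolated protein (Bos taurus) with 5-hydroxytryptamine receptor 1D (Homo sapiens) as the target (on this read-out lower numbers stand for stronger inhibition and higher numbers for weaker inhibition), compound 3, `c1ccc2c(c1)CCC(CNCCCNc1ccncn1)O2`, gives 10 nM, the lowest of the two numbers in hand. Compound 1, `c1ccc2c(c1)CC(CNCCCNC1=NCCCN1)O2`, gives 126 nM, a gap beyond the usual scatter. Compound 2, `c1ccc2c(c1)CCCC(CNCCCNC1=NCCCN1)O2`, returns only a limit of the assay, > 1000 nM. That reading is the one described as the limit of > 1000 nM in this assay, at which 1 of the 3 values shown sits. Compound 4, `O=C1CCCN=C(NCCCNCC2CCc3ccccc3O2)N1`, is not yet measured; it differs from compound 3 in a group of 8 heavy atoms (5 carbon, 2 nitrogen, 1 oxygen; one seven-membered non-aromatic ring with 2 hetero atoms) in place of a group of 6 heavy atoms (4 carbon, 2 nitrogen; one six-membered aromatic ring with 2 hetero atoms), on an amine nitrogen. Within the data shown here, no measured pair isolates this change. A weakening beyond the scatter is expected, the anticipated step being a 12-fold higher number from compound 3 to compound 4 (1.08 log units; beyond the scatter). Compound 4 is estimated at 120 nM, between 25 nM and 600 nM.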

Compound 4, half-maximal inhibitory concentration: 158 nM
Compound 4: middle estimate off by 1.3-fold (0.12 log units), on the low side, within the range that was stated.
By their numbers in this assay, from the lowest: compound 3; then compounds 1 and 4 (each within the scatter of the next). At a limit, above all of these: compound 2.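

Swapping pyrimidin-4-yl for the seven-membered non-aromatic ring with 2 hetero atoms on the amine nitrogen gives a 16-fold higher number from compound 3 to compound 4 (1.20 log units; beyond the scatter), the first single-place comparison in the series. At this position, on this core, the group therefore matters, and pyrimidin-4-yl is the better of the two. No measured property on hand accounts for the step.

Still open, on these data alone, is whether ring size or aromatic character carries the difference. A pyridin-4-yl or a six-membered non-aromatic ring on the same nitrogen would separate the two.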